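The source may report more compounds than this note shows. Statements on the series, on what has been measured and on what is new or still open speak of the compounds shown alone.

In an ADME assay on HEK293 cells (Homo sapiens) for inhibition, read by CellTiter-Glo, with a stated time of 96 h, tested at 100 uM (a higher number here means more inhibition at the concentration tested (going by the name of the read-out), a lower number less inhibition), compound 2 `CC(C)(C)OC(=O)/C=C\NC(=O)[C@@H](O)C(C)(C)CO` gives -11%, the lower of the two numbers recorded, although compound 1 `CC(C)(C)OC(=O)/C=C/NC(=O)[C@H](O)C(C)(C)CO` gives -1% and the step of a number 10 percentage points lower from compound 1 to compound 2 (within the scatter) lies within the scatter; these two differ only in configuration (the fact that compounds 1 and 2 differ only in the configuration as drawn). Compound 3 `CC(C)(CO)[C@H](O)C(=O)N/C=C\C(=O)OCc1ccccc1` carries benzyl in place of tert-butyl on an oxygen next to a carbonyl group. Among the compounds with values here, no measured step bears on such a change, since the single recorded step concerns configuration alone. The expected step is therefore none beyond the scatter, a number 6 percentage points higher from compound 2 to compound 3 (within the scatter). Compound 3 is estimated at -5%, within a range from -25% to 15%.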

Compound 3, a percentage reported as inhibition, at one concentration (the size of the read-out at that concentration, not a potency): -7%
For compound 3 the middle estimate is 2 percentage points above the measured one; the range from low to high includes it.
By their numbers in this assay, from the lowest: compounds 2, 3 and 1 (each within the scatter of the next).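

Putting benzyl in place of tert-butyl on an oxygen next to a carbonyl group gives a number 4 percentage points higher from compound 2 to compound 3 (within the scatter) in this assay, so a six-membered aromatic ring of carbon only can stand at this place without the number leaving the scatter. Within the data shown here, this is the first change of group seen, since the earlier step concerned configuration alone. No recorded fact bears on this step.

The compounds shown leave open how a methyl ester or a free carboxylic acid would read here. They also leave open whether benzyl gives the same reading with the double bond drawn E.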